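The compounds below may be only part of what the source reports. "The series", "measured", "known", "first", "only" and "open" are said of these compounds alone.

In a functional assay on PC-3 cells (Homo sapiens) for cytotoxicity, read by MTT assay, with a stated time of 72 h (a higher number here means a weaker inhibitor, a lower number a stronger inhibitor), compound 1 (`CNC(=O)c1cc(Oc2ccc(C3=NNC(c4ccc(C#N)cc4)C3)cc2)ccn1`) reads 9910 nM while compound 2 (`CNC(=O)c1cc(Oc2ccc(C3=NNC(c4ccc(F)cc4)C3)cc2)ccn1`) reads 6770 nM and so stands level with it, within the scatter. Compound 3 (`CNC(=O)c1cc(Oc2ccc(C3=NN(C(N)=S)C(c4ccc(F)cc4)C3)cc2)ccn1`) departs from compound 2 at a single place. The change (a group of 3 heavy atoms (1 carbon, 1 nitrogen, 1 sulfur; no ring) in place of a hydrogen atom, on an amine nitrogen in a ring) falls on an amine nitrogen in a ring, next to the ring atom that bears a 4-fluorophenyl group. Among the compounds with values here, the one measured step (a 1.5-fold lower number from compound 1 to compound 2 (0.17 log units; within the scatter)) sits on an aromatic carbon, so no measurement touches this nitrogen, and that small step is only a weak guide. No step beyond the scatter is therefore expected in this assay for this change, though with little confidence. The expected step (a 1.2-fold lower number from compound 2 to compound 3 (0.09 log units; within the scatter)) remains an estimate with a wide margin. For compound 3 the estimated value is 5500 nM with an expected range from 1500 nM to 18000 nM for now.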

Compound 3, half-maximal inhibitory concentration: > 50000 nM
Compound 3: only a limit was reported; the forecaster's own chance of this, stated with the estimate: 10%; middle value at least 9.0-fold (0.95 log units) away from the limit.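

In this assay, within the data shown here, the group of 3 heavy atoms (1 carbon, 1 nitrogen, 1 sulfur; no ring) in place of the hydrogen on the amine nitrogen in a ring gives an at least 7.3-fold higher number from compound 2 to compound 3 (0.86 log units; beyond the scatter), the only step here beyond the scatter. The earlier step, a 1.5-fold lower number from compound 1 to compound 2 (0.17 log units; within the scatter), lay on an aromatic carbon and said nothing about this nitrogen; the new step shows that the number in this assay does respond to what this nitrogen carries. Compound 3 stands at a limit and not at a number, so the full size of the step stays unknown: the limit of > 50000 nM in this assay, at which 1 of the 3 values shown sits.

Among the compounds shown, this nitrogen carries only hydrogen or this one group, so it remains open whether the sulfur or the group as a whole goes with the higher number. A methyl group, an acetyl group or the matching group with a carbonyl in place of the sulfur-bearing carbon would each test a different part of that question.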